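A few compounds are considered here, and "the series" means these few. Any claim that something is new, unique, unknown or untested is made for them only; others in the source may bear on it.

The measured compounds and their values:

Compound 1, `Cc1ccc(-c2nnc(SCCCN3CCN(c4nc5ccccc5o4)CC3)o2)cc1` — 106000 nM
Compound 2, `Clc1ccc(-c2nnc(SCCCN3CCN(c4nc5ccccc5o4)CC3)o2)cc1` — 127000 nM
Compound 3, `Cc1ccc(-c2nnc(SCCCN3CCN(c4nc5ccccc5s4)CC3)o2)cc1` — 53900 nM

All three were tested in a functional assay on A549 cells (Homo sapiens) for inhibition, read by MTT assay, with a stated time of 72 h; a lower number here means a stronger inhibitor, a higher number a weaker inhibitor. Compound 1 and compound 2 share a core and differ only in one group: chloro in place of methyl on an aromatic carbon. That change gave a 1.2-fold higher number from compound 1 to compound 2 (0.08 log units; within the scatter), so the two compounds are not told apart by this assay. Compound 3 has a different core from compound 1: 1,3-benzothiazol-2-yl in place of 1,3-benzoxazol-2-yl on an amine nitrogen in a ring. The step there was a 2.0-fold lower number from compound 1 to compound 3 (0.29 log units; within the scatter), again too small to count as a real difference. Compound 3 has the lowest number of the three, but its gap to compound 1 is within the scatter, so it cannot be called the strongest of the set.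

Compound 4, `Clc1ccc(-c2nnc(SCCCN3CCN(c4nc5ccccc5s4)CC3)o2)cc1`, has not yet been measured. It stands to compound 3 as compound 2 stands to compound 1: chloro in place of methyl on an aromatic carbon. The surroundings of the change are the same in both pairs, so this is the same change, made on the core of compound 3 instead of the core of compound 1.

For the measured compounds named here, the only guide for compound 4 is the earlier pair, where the same change gave a 1.2-fold higher number from compound 1 to compound 2 (0.08 log units; within the scatter). The same near-flat outcome is expected here, so the estimated step is a 1.2-fold higher number from compound 3 to compound 4 (0.08 log units; within the scatter). On that basis compound 4 is expected to give about 65000 nM in this assay, with a range from 30000 nM to 140000 nM allowing for the usual scatter.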

Compound 4, half-maximal inhibitory concentration: 110000 nM
Compound 4: the middle estimate sits 1.7-fold (0.23 log units) below what was measured, within the range that was stated.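

In this assay, chloro in place of methyl gave a 2.0-fold higher number from compound 3 to compound 4 (0.31 log units; beyond the scatter), a modest step, yet it cannot be told apart from the step that the same change gave on the core of compound 1: the same change on two cores in this assay, a 1.2-fold higher number (0.08 log units; within the scatter) from compound 1 to compound 2 and a 2.0-fold higher number (0.31 log units; beyond the scatter) from compound 3 to compound 4, 1.7-fold (0.23 log units) apart, within the scatter of two such steps

The other change, 1,3-benzothiazol-2-yl in place of 1,3-benzoxazol-2-yl, gave a 1.2-fold lower number from compound 2 to compound 4 (0.06 log units; within the scatter), so compound 2 and compound 4 are not separated by this assay, and this step also agrees with its earlier counterpart: the same change on two cores in this assay, a 2.0-fold lower number (0.29 log units; within the scatter) from compound 1 to compound 3 and a 1.2-fold lower number (0.06 log units; within the scatter) from compound 2 to compound 4, 1.7-fold (0.23 log units) apart, within the scatter of two such steps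

For the compounds shown here, the two comparisons therefore fit the idea that each change carries over from one core to the other, but each rests on only two steps close to the scatter, so they do not show that the size of a step is truly the same on both cores, nor that it would hold on any further core.

From the compounds shown here alone, what a methoxy group or a nitrile would do in place of the methyl or chloro remains open, as does the effect of a longer chain between the two halves of the molecule. All four compounds are also compared in a single cell assay, so whether these steps would look the same in other cells is open too.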